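The compounds below may be only part of what the source reports. "The series", "measured", "known", "first", "only" and "open" are said of these compounds alone.

Compound 1 `COc1cc(Oc2cccc(Nc3ccccc3)c2)cc(OC)c1CNCCNC(C)=O`: 11900 nM
Compound 2 `COc1cc(Oc2cccc(Nc3ccccc3)c2)cc(OC)c1CCO`: > 20000 nM

Compound 1 carries a (2-acetamidoethyl)amino group on a saturated chain carbon bound to an aromatic carbon, and in a functional assay on SW-620 cells (Homo sapiens) for inhibition, read by MTT assay, with a stated time of 72 h (on this read-out higher numbers stand for weaker inhibition and lower numbers for stronger inhibition), compound 1 gives 11900 nM. Compound 2 has hydroxymethyl at that place. In this assay compound 2 reaches only > 20000 nM, which is a limit of the assay and not a number, so where compound 2 stands is known only as that limit (the limit of > 20000 nM in this assay, at which 1 of the 2 values shown sits). Going by the values given here, the one measured step, an at least 1.6-fold higher number from compound 1 to compound 2 (0.22 log units; that floor lies within the scatter), therefore sets no more than a floor.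

Compound 3 `COc1cc(Oc2cccc(Nc3ccccc3)c2)cc(OC)c1CNCc1ccc(O)cc1` is not yet measured. It differs from compound 2 by (4-hydroxybenzyl)amino in place of hydroxymethyl on a saturated chain carbon bound to an aromatic carbon. Among the compounds with values here, the only measured step that bears on this change is an at least 1.6-fold higher number from compound 1 to compound 2 (0.22 log units; that floor lies within the scatter), in which the loss of an amine from that chain carbon went with a weaker number. Compound 3 restores an amine at the same carbon, as in compound 1, so the expectation is a return toward the region of compound 1, with the limit on compound 2 leaving the size open. Compound 3 is thus expected to give about 12000 nM, between 4000 nM and 30000 nM. That estimate amounts to an expected at least 1.6-fold lower number from compound 2 to compound 3 (0.22 log units; that floor lies within the scatter).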

Compound 3, half-maximal inhibitory concentration: 7940 nM
Beside the measured number, compound 3's estimate is 1.5-fold (0.18 log units) above it; the measured number falls inside the stated range.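

In this assay, going by these compounds alone, the change to (4-hydroxybenzyl)amino gives an at least 2.5-fold lower number from compound 2 to compound 3 (0.40 log units; beyond the scatter), the first step at this place that lies beyond the scatter, so hydroxymethyl and an amine-bearing group on this saturated chain carbon now separate. The true size of that step remains unknown, as compound 2 stands only at a limit of the assay, which makes this step a floor: the limit of > 20000 nM in this assay, at which 1 of the 3 values shown sits.

On the amine nitrogen itself, 4-hydroxyphenyl in place of acetamidomethyl gives a 1.5-fold lower number from compound 1 to compound 3 (0.18 log units; within the scatter), which lies within the scatter, so two quite different groups on that nitrogen cannot be told apart in this assay.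

The compounds shown leave open whether the nitrogen alone accounts for the step, as it carries a further substituent in both compound 1 and compound 3; a plain amino group on the same chain carbon would separate the nitrogen from what it carries. Also open, from the compounds shown here alone, is what the hydroxyl of the 4-hydroxybenzyl group contributes, which a plain benzyl group or a 4-methoxybenzyl group on that nitrogen would address.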